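The compounds below may be only part of what the source reports. "The series", "measured", "known", "first", "only" and "open" are said of these compounds alone.

Measured compounds in an assay on COS-7 cells for inhibition of sodium/nucleoside cotransporter 2 (Homo sapiens), read by scintillation counting, in the presence of a further agent that is not named here; on this read-out higher numbers stand for weaker inhibition and lower numbers for stronger inhibition:
- compound 1, `Nc1ncnc2c1nc(NCCCc1ccccc1)n2[C@@H]1O[C@H](CO)[C@@H](O)[C@H]1O`, gives 536000 nM
- compound 2, `CNC(=O)OC[C@H]1O[C@@H](n2cnc3c(N)ncnc32)[C@H](O)[C@@H]1O`, gives > 100000 nM, which is a limit of the assay and not a number
- compound 3, `CCNC(=O)OC[C@H]1O[C@@H](n2cnc3c(N)ncnc32)[C@H](O)[C@@H]1O`, gives > 100000 nM, again a limit of the assay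

Going by the values given here, compound 1 therefore holds the only number among the three; the other two values sit at the limit of > 100000 nM in this assay, at which 2 of the 3 values shown sit. Among the compounds with values here, the one change between measured compounds, a step that the two limits leave unreadable from compound 2 to compound 3, is unreadable because both values are limits, so it says nothing about size or direction. Compound 4, `Cc1ccccc1CNc1nc2c(N)ncnc2n1[C@@H]1O[C@H](CO)[C@@H](O)[C@H]1O`, is not yet measured. It differs from compound 1 by 2-methylphenyl in place of phenethyl on a saturated chain carbon bound to a nitrogen on an aromatic ring. Within the data shown here, no measured step touches the chain bound to the nitrogen on the aromatic ring, so there is nothing to read a size from. With only the weak number of compound 1 to lean on, compound 4 is expected to stay in the same weak region, the expected step of a 1.2-fold lower number from compound 1 to compound 4 (0.08 log units; within the scatter) being no larger than scatter. Compound 4 is estimated at 450000 nM, between 120000 nM and 1700000 nM, with a fair chance of a limit.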

Compound 4, half-maximal inhibitory concentration: 65000 nM
Compound 4: the middle estimate sits 6.9-fold (0.84 log units) above what was measured; the measured number lies below the stated range.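

In this assay, going by these compounds alone, the chain on the nitrogen bound to the aromatic ring proves sensitive to change: going from 3-phenylpropyl to 2-methylbenzyl gives an 8.2-fold lower number from compound 1 to compound 4 (0.92 log units; beyond the scatter), the first step of readable size here, as the earlier step between two limits could not be read. The entering and leaving groups are alike in what is counted for them, each with one six-membered aromatic ring of carbon only, no hydrogen-bond donors or acceptors and no net charge. Nothing shown gives a reason for this step.

The step shortens the chain and adds the methyl together, so the compounds shown leave open which of the two carries the difference, and a plain benzyl group would separate them. Also open, from the compounds shown here alone, is how an amine or a carboxylic acid on that aromatic ring would read.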